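Trimming the long chain of compound 2

The source may hold more compounds than are shown below. What is called first, only, known or untested is meant among the compounds shown, and "the series" means these compounds.

Compound 1 `Cc1cc(O)c(C(=O)NCCCc2ccccc2)c(=O)o1`: 143000 nM
Compound 2 `CCCCCCCCCCCCCCNC(=O)c1c(O)cc(C)oc1=O`: > 200000 nM

These values come from an ADME assay on L929 cells (Mus musculus, culture collection number NCTC 929) for cytotoxicity, read by MTT assay, with a stated time of 72 h; on this read-out lower numbers stand for stronger inhibition and higher numbers for weaker inhibition. Compound 2 stands at > 200000 nM, which is a limit of the assay and not a number. Compound 3 `CCCCCCCNC(=O)c1c(O)cc(C)oc1=O` is still unmeasured and differs from compound 2 by hydrogen in place of heptyl on a saturated chain carbon, seven bonds along the chain from an amide-type nitrogen. For the measured compounds named here, with compound 1 at 143000 nM as the only numeric guide, a small shift towards stronger inhibition is expected, an at least 1.3-fold lower number from compound 2 to compound 3 (0.12 log units; that floor lies within the scatter). The estimate for compound 3 is 150000 nM, with an expected range of 70000 nM to 200000 nM.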

Compound 3, half-maximal inhibitory concentration: 187000 nM
For compound 3 the middle estimate is 1.2-fold (0.10 log units) below the measured one; measured number inside the range.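

Compound 2 stands at a limit of the assay and not at a number: the limit of > 200000 nM in this assay, at which 1 of the 3 values shown sits. With hydrogen in place of heptyl, the step reads an at least 1.0-fold lower number from compound 2 to compound 3 (0.02 log units; that floor lies within the scatter), so only a floor is known and it shows no firm gain. With butyl in place of phenyl, the step reads a 1.3-fold higher number from compound 1 to compound 3 (0.12 log units; within the scatter), so compound 1 and compound 3 cannot be told apart in this assay.

Going by these compounds, whether a hydroxyl, an amine or a carboxylic acid on this chain would move the number remains open. On these data alone, the true value of compound 2 also remains open.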